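The source may report more compounds than this note shows. Statements on the series, on what has been measured and on what is new or still open speak of the compounds shown alone.

Measured so far in a functional assay on B16-F0 cells (Mus musculus) for inhibition, read by CCK-8 assay, with a stated time of 48 h; a lower number here means a stronger inhibitor, a higher number a weaker inhibitor:
- compound 1 `COc1ccc(-c2cc3nccc(-c4cc(OC)c(OC)c(OC)c4)n3n2)cc1N`: 88 nM
- compound 2 `COc1cc(-c2ccnc3cc(-c4c[nH]c5ccccc45)nn23)cc(OC)c1OC`: 40 nM
- compound 3 `COc1cc(-c2ccnc3cc(-c4ccc5ccn(C)c5c4)nn23)cc(OC)c1OC`: 657 nM

Compound 1 stands second highest of the three numbers; the nearest is compound 2, the step being a 2.2-fold lower number from compound 1 to compound 2 (0.34 log units; beyond the scatter), and the furthest is compound 3, with a 7.5-fold higher number from compound 1 to compound 3 (0.87 log units; beyond the scatter).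

Compound 4 `COc1cc(-c2ccnc3cc(-c4ccc(N(C)C)cc4)nn23)cc(OC)c1OC` differs from compound 1 in one place: 4-(dimethylamino)phenyl in place of 3-amino-4-methoxyphenyl on an aromatic carbon.

Both measured steps from compound 1 exchange the same group at the same position and so bear on this change, yet they pull in opposite directions, one modest and downward, the other modest and upward; the gap between them, a 16-fold higher number from compound 2 to compound 3 (1.22 log units; beyond the scatter), is large. Among the measured compounds shown here, no measured compound carries a 4-(dimethylamino)phenyl, so the direction is open. A small step upward, within the range spanned by compounds 2 and 3, is expected for compound 4: a 1.7-fold higher number from compound 1 to compound 4 (0.23 log units; within the scatter). The estimate for compound 4 in this assay is 150 nM, with a range from 40 nM to 600 nM.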

Compound 4, half-maximal inhibitory concentration: 702 nM
Estimate against measurement, compound 4: 4.7-fold (0.67 log units) below; the measured number lies above the stated range.
By their numbers in this assay, from the lowest: compound 2; then compound 1; then compounds 3 and 4 (each within the scatter of the next).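

In this assay, 4-(dimethylamino)phenyl on this aromatic carbon of the five-membered ring gives an 8.0-fold higher number from compound 1 to compound 4 (0.90 log units; beyond the scatter) and an 18-fold higher number from compound 2 to compound 4 (1.24 log units; beyond the scatter), so the change from either of those groups costs strength. With a 1.1-fold higher number from compound 3 to compound 4 (0.03 log units; within the scatter), it sits level with 1-methyl-1H-indol-6-yl, and two different groups now share the high end of the series. No available data explain these steps.

Open, on these data alone, is whether a 4-aminophenyl, with a free amine in the same place as the dimethylamino, would recover the lower numbers. An unsubstituted phenyl would give the baseline.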